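The compounds below may be only part of what the source reports. "The series", "measured", "known", "first", "only" and "open" are said of these compounds alone.

Measured compounds in a functional assay on COLO 205 cells (Homo sapiens) for inhibition, read by sulforhodamine B assay, with a stated time of 48 h, tested at 50 uM; on this read-out higher numbers stand for more inhibition of growth at the one concentration tested and lower numbers for less inhibition of growth:
Compound 1 `O=C1C(=O)N(CCCCCn2cc(COc3cc(=O)oc4ccccc34)nn2)c2ccc(I)cc21` gives 30%.
Compound 2 `O=C1C(=O)N(CCCn2cc(COc3cc(=O)oc4ccccc34)nn2)c2ccccc21` gives 75%.
Compound 3 `O=C1C(=O)N(CCCn2cc(COc3cc(=O)oc4ccccc34)nn2)c2ccc(I)cc21` gives 56%.

Compound 1 stands lowest of the three; compound 3 lies nearest to it and compound 2 furthest, both gaps beyond the scatter. Compound 2 and compound 3 share one core and differ in one place only: hydrogen in place of iodo on an aromatic carbon. That step reads a number 19 percentage points higher from compound 3 to compound 2 (beyond the scatter). Compound 1 and compound 3 have different cores; the difference between the two cores is not broken down here.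

Compound 4 `O=C1C(=O)N(CCCCCn2cc(COc3cc(=O)oc4ccccc34)nn2)c2ccccc21` is not yet measured. It is related to compound 1 by hydrogen in place of iodo on an aromatic carbon, the same change as between compound 3 and compound 2, the two place descriptions agreeing word for word. Going by the values given here, the expectation rests on the single prior instance of this change, a number 19 percentage points higher from compound 3 to compound 2 (beyond the scatter), applied to compound 1 at 30%. Compound 4 is therefore expected to give about 49% in this assay, the estimate spanning 33% to 65%. The expected step, a number 19 percentage points higher from compound 1 to compound 4 (beyond the scatter), is taken to match the earlier one in size; with one prior example and a different core, the range is kept wide.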

Compound 4, percent growth inhibition at one concentration: 62%
Estimate against measurement, compound 4: 13 percentage points below, and the stated range covers the measured number.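

In this assay, hydrogen in place of iodo on the core of compound 1 gives a number 32 percentage points higher from compound 1 to compound 4 (beyond the scatter). Set beside the earlier step, the change carries across the two cores in direction, and the two steps do not differ in size beyond what repeated measurements allow: the same change on two cores in this assay, a number 19 percentage points higher (beyond the scatter) from compound 3 to compound 2 and a number 32 percentage points higher (beyond the scatter) from compound 1 to compound 4, 13 percentage points apart, within the scatter of two such steps. This rests on two matched pairs read at one concentration in one cell line, so it shows that the change transferred between these two cores only, and it does not show that the same step would hold on any further core or explain why removing the iodo group raises the read-out.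

The compounds shown leave open whether a smaller halogen such as fluoro or chloro on the same aromatic carbon would fall with the iodo or with the hydrogen compounds. They also leave open how an amine or a carboxylic acid at that place, or a longer chain, would read in this assay.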